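The source may hold more compounds than are shown below. What is called first, only, known or untested is meant among the compounds shown, and "the series" means these compounds.

Compound 1 `Cc1ccc(/C=N/N(C(=O)c2ccccc2)C(=O)c2ccncc2)cc1` and compound 2 `COc1cccc(OC)c1/C=N/NC(=O)c1ccncc1` set the frame. In an ADME assay on HeLa cells (Homo sapiens) for cytotoxicity (on this read-out lower numbers stand for higher toxicity in this test and higher numbers for lower toxicity in this test), compound 1 gives 100 ug/mL, and in this assay compound 2 gives 100 ug/mL, level with compound 1 at the digits shown and within the scatter. Compound 3 `COc1cccc(OC)c1/C=N/N(C(=O)c1ccccc1)C(=O)c1ccncc1` differs from compound 2 by benzoyl in place of hydrogen on an amide-type nitrogen. Compound 1 already carries a benzoyl on its amide-type nitrogen and still gives 100 ug/mL, so no step beyond the scatter is expected from compound 2 to compound 3, that is no change at the digits printed from compound 2 to compound 3 (within the scatter). Compound 3 is therefore expected to give 100 ug/mL, with a range of 50 ug/mL to 200 ug/mL.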

Compound 3, minimum cytotoxic concentration: 20 ug/mL
Beside the measured number, compound 3's estimate is 5.0-fold (0.70 log units) above it; measured number below the stated range.
By their numbers in this assay, from the lowest: compound 3; then compounds 1 and 2 (each within the scatter of the next).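

In this assay, among these compounds, the amide-type nitrogen emerges as a position that responds: benzoyl in place of hydrogen gives a 5.0-fold lower number from compound 2 to compound 3 (0.70 log units; beyond the scatter) and is the first step that can be read between compounds differing in one place. This reading covers one change on one core, so it gives direction and size only for this pair. Nothing available explains the change in toxicity in this test.

As far as these compounds go, whether acetyl, a longer chain or an amine on this nitrogen would behave like benzoyl stays open. From the compounds shown here alone, how the same replacement reads on the core of compound 1 also stays open.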